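Expected Rat Exposure After Swapping the Pyridinyl Group

A few compounds are considered here, and "the series" means these few. Any claim that something is new, unique, unknown or untested is made for them only; others in the source may bear on it.

Of the compounds shown here, three with a shared core have been measured in an ADME assay on the whole organism (Rattus norvegicus), at a dose of 2 mg/kg by the oral route; on this read-out lower numbers stand for lower exposure and higher numbers for higher exposure at the dose given. Compound 1 `COc1cc(OCc2csc(-c3ccc(C(C)(C)O)cc3)n2)c2cc(-c3cn4nc(OC)sc4n3)oc2c1` gives 505 ng.h/mL. Compound 2 `COc1cc(OCc2cccc(-c3ccc(C(F)(F)F)cn3)c2)c2cc(-c3cn4nc(OC)sc4n3)oc2c1` gives 459 ng.h/mL, and compound 3 `COc1cc(OCc2cccc(-c3ccc(C#N)cn3)c2)c2cc(-c3cn4nc(OC)sc4n3)oc2c1` gives 464 ng.h/mL. Compound 2 holds the lowest of the three numbers, yet all three lie within the scatter of one another, so no order can be read from them. Compound 4 `COc1cc(OCc2cccc(-c3ccc(OC)nc3)c2)c2cc(-c3cn4nc(OC)sc4n3)oc2c1` is not yet measured; it differs from compound 2 by 6-methoxypyridin-3-yl in place of 5-(trifluoromethyl)pyridin-2-yl on an aromatic carbon. Within the data shown here, the only measured step that bears on this change, a 1.0-fold higher number from compound 2 to compound 3 (0.00 log units; within the scatter), stayed within the scatter. Nothing in these data points to a shift beyond the scatter, so compound 4 is expected to give 450 ng.h/mL, within a range from 200 ng.h/mL to 1000 ng.h/mL. That estimate means a 1.0-fold lower number from compound 2 to compound 4 (0.01 log units; within the scatter) is expected.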

Compound 4, area under the concentration-time curve: 1800 ng.h/mL
The estimate for compound 4 lay 4.0-fold (0.60 log units) below the measured number; measured number above the stated range.
By their numbers in this assay, from the lowest: compounds 2, 3 and 1 (each within the scatter of the next); then compound 4.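

In this assay the group at this place clearly matters: 6-methoxypyridin-3-yl gives a higher number than 5-(trifluoromethyl)pyridin-2-yl (a 3.9-fold higher number from compound 2 to compound 4 (0.59 log units; beyond the scatter)) and than 5-cyanopyridin-2-yl (a 3.9-fold higher number from compound 3 to compound 4 (0.59 log units; beyond the scatter)). The earlier swap of trifluoromethyl for cyano had stayed within the scatter, so the two groups leaving here offered no sign of this room for change. Nothing measured here explains the rise.

Since the whole pyridinyl group changes, the methoxy group cannot be separated from the different pyridinyl attachment. As far as these compounds go, whether an amine or a longer ether chain in place of methoxy would give similar exposure also stays open.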